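The source may hold more compounds than are shown below. What is called first, only, known or untested is meant among the compounds shown, and "the series" means these compounds.

Measured compounds in a functional assay on MCF7 cells (Homo sapiens) for antiproliferative activity, read by MTT assay; a lower number here means a stronger inhibitor, a higher number a weaker inhibitor:

compound 1, `COc1ccc(-c2nc(N3CCNCC3)nc3ccccc23)c(OC)c1`, 50 ug/mL 
compound 2, `c1ccc2c(c1)ccn2-c1nc(N2CCCCC2)nc2ccccc12`, 50 ug/mL 
compound 3, `Cn1cc(-c2nc(N3CCNCC3)nc3ccccc23)c2ccccc21`, 50 ug/mL 

Compound 1 stands level with compound 2 and compound 3 at the digits shown: the three values lie within the scatter of one another, so no order among them can be read. For the measured compounds named here, no step between measured compounds in this assay is available for the change considered here.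

Compound 4, `COc1cc(OC)c(-c2nc(N3CCNCC3)nc3ccccc23)c(OC)c1`, is not yet measured. From compound 1 it differs by one change: methoxy in place of hydrogen on an aromatic carbon. The new group sits meta to two methoxy groups, ortho to a large group, on the six-membered carbon ring.

With three flat values and no shown step, no shift beyond the scatter is expected: the step of a 1.1-fold lower number from compound 1 to compound 4 (0.05 log units; within the scatter) is estimated as small. Compound 4 is expected to give about 45 ug/mL, between 20 ug/mL and 80 ug/mL.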

Compound 4, half-maximal inhibitory concentration: 50 ug/mL
For compound 4 the middle estimate is 1.1-fold (0.05 log units) below the measured one; low and high end bracket the measured number.
By their numbers in this assay, from the lowest: compounds 1, 2, 3 and 4 (each within the scatter of the next).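

In this assay, for the compounds shown here, methoxy in place of hydrogen on an aromatic carbon, ortho to a large group and meta to two methoxy groups, gives no change at the digits printed from compound 1 to compound 4 (within the scatter) and provides the first single-place comparison. At this position, this change therefore leaves the read-out flat. No available measurement bears on the reason for this result. Still open, going by these compounds, is whether an amine, a carboxylic acid or a longer chain at the same position would move the number away from that of compound 1.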